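The source may hold more compounds than are shown below. What is called first, only, known or untested is meant among the compounds shown, and "the series" means these compounds.

Series notes. In a functional assay on CHO-K1 cells for antagonist activity at adenosine receptor A1 (Homo sapiens), read by a beta-galactosidase reporter and cAMP accumulation, with stated times of 15 min and 6 h (on this read-out higher numbers stand for weaker inhibition and lower numbers for stronger inhibition), compound 1 `Nc1nc(-c2ncco2)nc2sc(Cc3ccccc3)cc12` gives 310 nM. Compound 2 `Cc1csc(-c2nc(N)c3cc(Cc4ccccc4)sc3n2)n1` carries a 4-methyl-1,3-thiazol-2-yl in place of the 1,3-oxazol-2-yl, and in this assay compound 2 gives 1490 nM; the step is a 4.8-fold higher number from compound 1 to compound 2 (0.68 log units; beyond the scatter). Among the compounds with values here, compound 2 therefore stands at the highest of the two numbers measured so far, with compound 1 as its nearest neighbour.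

Compound 3 `Cc1nc(-c2nc(N)c3cc(Cc4ccccc4)sc3n2)cs1` is the next point: 2-methyl-1,3-thiazol-4-yl in place of 4-methyl-1,3-thiazol-2-yl on an aromatic carbon. Within the data shown here, the one measured step that bears on this position is a 4.8-fold higher number from compound 1 to compound 2 (0.68 log units; beyond the scatter), which exchanged one five-membered ring for another. The change to compound 3 keeps the same ring atoms and alters only how the thiazole is joined, so a smaller effect than that step is expected, and the direction is left open. The working estimate for compound 3 in this assay is 1000 nM, with a range of 350 nM to 3000 nM, which amounts to an expected 1.5-fold lower number from compound 2 to compound 3 (0.17 log units; within the scatter).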

Compound 3, inhibition constant: 263 nM
Compound 3: middle estimate off by 3.8-fold (0.58 log units), on the high side; the measured number lies below the stated range.
By their numbers in this assay, from the lowest: compounds 3 and 1 (each within the scatter of the next); then compound 2.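

In this assay, the same thiazole atoms joined differently give a 5.7-fold lower number from compound 2 to compound 3 (0.75 log units; beyond the scatter), so this position responds to how the ring is attached and its methyl placed, not only to which ring is present. Within the data shown here, the 2-methyl-1,3-thiazol-4-yl and the 1,3-oxazol-2-yl cannot be told apart, at a 1.2-fold lower number from compound 1 to compound 3 (0.07 log units; within the scatter), which leaves 4-methyl-1,3-thiazol-2-yl as the only one of the three groups set apart on this read-out. Nothing at hand accounts for the difference between the two thiazole attachments.

Still open, going by these compounds, is whether the step follows the ring attachment or the place of the methyl, a question that unsubstituted 1,3-thiazol-2-yl and 1,3-thiazol-4-yl rings would address. Also open, on these data alone, is how a six-membered ring such as pyridin-2-yl would read at this position in this assay.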